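This account rests on a few compounds, and the source may have more. Where it says the series, first, only, none or still open, it means among the compounds named here.

Measured compounds:
Compound 1, `CCCCCn1c(-c2ccco2)nc2c(NCCCOC)ccnc21` — in an assay on isolated protein for inhibition of high affinity 3',5'-cyclic-AMP phosphodiesterase 7A (Homo sapiens), read by cAMP accumulation, with a stated time of 20 min (a higher number here means a weaker inhibitor, a lower number a stronger inhibitor), compound 1 gives 34200 nM.
Compound 2, `CCCCCn1c(-c2ccco2)nc2c(NCCCO)ccnc21` — in this assay compound 2 gives 63600 nM.

Compound 2 has the higher of the two numbers, but the step of a 1.9-fold higher number from compound 1 to compound 2 (0.27 log units; within the scatter) lies within the scatter, so the two compounds cannot be told apart on these values. Compound 3, `CCCCCn1c(-c2ccco2)nc2c(N(C)CCCO)ccnc21`, has not yet been measured. It differs from compound 2 by methyl in place of hydrogen on a nitrogen on an aromatic ring. Among the compounds with values here, no measured pair shows a methyl entering on this nitrogen; the only measured step, from compound 1 to compound 2, concerns the oxygen at the end of the chain and was within the scatter, so it says nothing direct about the change in hand. Within the data shown here, with no step that bears on it, the expectation for compound 3 rests on compound 2 alone. Compound 3 is therefore expected to land near compound 2, with a step of a 1.1-fold lower number from compound 2 to compound 3 (0.03 log units; within the scatter) and a wide range, 20000 nM to 200000 nM. The estimate for compound 3 is 60000 nM.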

Compound 3, half-maximal inhibitory concentration: 18900 nM
For compound 3 the middle estimate is 3.2-fold (0.50 log units) above the measured one; measured number below the stated range.
By their numbers in this assay, from the lowest: compounds 3, 1 and 2 (each within the scatter of the next, the first and the last beyond it).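

In this assay, within the data shown here, methyl in place of hydrogen on the nitrogen on an aromatic ring gives a 3.4-fold lower number from compound 2 to compound 3 (0.53 log units; beyond the scatter), a modest change but the first step beyond the scatter, so a substituent on this nitrogen can move the number where the change at the chain's terminal oxygen did not. Taken together with the change at the end of the chain, replacing (3-methoxypropyl)amino with (3-hydroxypropyl)(methyl)amino gives a 1.8-fold lower number from compound 1 to compound 3 (0.26 log units; within the scatter), which lies within the scatter and leaves these two compounds indistinguishable. Nothing available explains the step from the added methyl.

On these data alone, whether the same methyl would have a similar effect with a methoxy group at the chain end remains open. So does the outcome with an ethyl group on this nitrogen, or with an amine or a carboxylic acid at the end of the chain.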